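From ethoxymethyl to butyl: estimating compound 4

The source may hold more compounds than are shown below. What is called first, only, known or untested is meant among the compounds shown, and "the series" means these compounds.

Compound 1 `CCCCc1[nH]c(=O)c(-c2nnc(Cc3ccccc3)o2)c(O)c1-c1c(OC)cccc1OC`: 87%
Compound 2 `COc1cccc(OC)c1-c1c(C2CCCC2)[nH]c(=O)c(-c2nnc(Cc3ccc(Cl)cc3)o2)c1O`: 80%
Compound 3 `CCOCc1[nH]c(=O)c(-c2nnc(Cc3ccc(Cl)cc3)o2)c(O)c1-c1c(OC)cccc1OC`: 94%

In an ADME assay on microsomes from liver (Homo sapiens) for metabolic stability, read by mass spectrometry, using NADPH, with a stated time of 10 min (on this read-out lower numbers stand for a less stable compound and higher numbers for a more stable compound), compound 3 gives 94%, the highest number of the three. Compound 1 gives 87%, which lies within the usual scatter of the value for compound 3. Compound 2 gives 80%, and only this gap goes beyond the scatter.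

The next compound to be measured is compound 4 `CCCCc1[nH]c(=O)c(-c2nnc(Cc3ccc(Cl)cc3)o2)c(O)c1-c1c(OC)cccc1OC`. It differs from compound 3 in a single place: propyl in place of ethoxy on a saturated chain carbon bound to an aromatic carbon. In words, this is propyl in place of ethoxy on a saturated chain carbon bound to an aromatic carbon, which can also be read as ethoxymethyl to butyl.

Going by the values given here, only one measured step touches this ethoxymethyl group: a number 14 percentage points higher from compound 2 to compound 3 (beyond the scatter), where ethoxymethyl takes the place of cyclopentyl. That step was modest, and it involved a different partner group, so it is only a loose guide. The butyl chain itself already appears in compound 1 at 87%, although that compound differs from compound 4 elsewhere.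

A small drop is therefore expected, and the estimated change is a number 8 percentage points lower from compound 3 to compound 4 (within the scatter). For compound 4 the expected value is 86%, with an estimated range from 74% to 95%.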

Compound 4, percent of the compound remaining: 66%
For compound 4 the middle estimate is 20 percentage points above the measured one; measured number below the stated range.
By their numbers in this assay, from the lowest: compound 4; then compounds 2, 1 and 3 (each within the scatter of the next, the first and the last beyond it).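

In this assay the change of ethoxymethyl to butyl keeps the count of heavy atoms and swaps only the oxygen for a carbon, yet it gives a number 28 percentage points lower from compound 3 to compound 4 (beyond the scatter) and so shows that this position responds strongly to that one atom, something the earlier step from cyclopentyl could not separate out. Butyl also compares poorly with the ring it can replace, with a number 14 percentage points lower from compound 2 to compound 4 (beyond the scatter) once the chloro group is present, so at this position, among compounds carrying chloro, ethoxymethyl, cyclopentyl and butyl form an order in which each printed step lies beyond the scatter. The third step, a number 21 percentage points lower from compound 1 to compound 4 (beyond the scatter) for chloro in place of hydrogen, shows that with butyl held fixed a change in a second place matters as well, so the good number of compound 1 does not carry over to its chloro partner.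

Nothing measured here explains why the oxygen or the chloro group has these effects. Still open, on these data alone, is whether ethoxymethyl keeps its advantage with hydrogen in place of chloro, and whether an amine or a longer ether chain at this position would behave like ethoxymethyl or like butyl.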